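This account rests on a few compounds, and the source may have more. Where it says the series, first, only, none or still open, it means among the compounds named here.

Three compounds have been measured in a functional assay on HepG2 cells (Homo sapiens) for inhibition, with a stated time of 72 h; on this read-out higher numbers stand for weaker inhibition and lower numbers for stronger inhibition:

Compound 3 `O=C(Nc1ccccc1)Nc1nc(Sc2c[nH]c3ccccc23)cc(N2CCN(Cc3ccccc3)CC2)n1` gives 8160 nM.
Compound 2 `COc1ccc(NC(=O)Nc2nc(Sc3c[nH]c4ccccc34)cc(N3CCCCC3)n2)cc1` gives 17100 nM.
Compound 1 `COc1ccc(NC(=O)Nc2nc(Sc3c[nH]c4ccccc34)cc(N3CCN(Cc4ccccc4)CC3)n2)cc1` gives 21400 nM.

Compound 3 stands lowest of the three, with compound 2 and compound 1 both giving higher numbers beyond the scatter. Compound 4 `Cc1cc(Cl)ccc1NC(=O)Nc1nc(Sc2c[nH]c3ccccc23)cc(N2CCN(Cc3ccccc3)CC2)n1` differs from compound 3 in one place: 4-chloro-2-methylphenyl in place of phenyl on an amide-type nitrogen. For the measured compounds named here, no measured step covers a chlorine or methyl entering this ring. Going by the values given here, the only step touching the same ring is a 2.6-fold lower number from compound 1 to compound 3 (0.42 log units; beyond the scatter), where a methoxy was removed, a modest move. That suggests changes on this ring shift the number modestly, but the direction here is not settled by the data. Compound 4 is therefore expected to land near compound 3, estimated at 6500 nM within 2500 nM to 18000 nM, a step of a 1.3-fold lower number from compound 3 to compound 4 (0.10 log units; within the scatter).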

Compound 4, half-maximal inhibitory concentration: 11700 nM
Estimate against measurement, compound 4: 1.8-fold (0.26 log units) below; low and high end bracket the measured number.
By their numbers in this assay, from the lowest: compounds 3, 4, 2 and 1 (each within the scatter of the next, the first and the last beyond it).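

Putting 4-chloro-2-methylphenyl on the amide-type nitrogen in place of phenyl gives a 1.4-fold higher number from compound 3 to compound 4 (0.16 log units; within the scatter) and, in place of 4-methoxyphenyl, gives a 1.8-fold lower number from compound 1 to compound 4 (0.26 log units; within the scatter) at the same place. This position therefore accepts a ring carrying both chlorine and methyl with no step beyond the scatter, unlike the removal of methoxy between compound 1 and compound 3. No outside data explain these steps.

As far as these compounds go, the separate contributions of the chlorine and the methyl remain open. So does the outcome with an amine or a carboxylic acid on this ring.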